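Chloro for Bromo on the Core of Compound 2

This account rests on a few compounds, and the source may have more. Where it says the series, first, only, none or still open, it means among the compounds named here.

Measured compounds and their values:
Compound 1, `CCN(CC)CN1C(=O)/C(=N\c2nc3ccc(C)cc3s2)c2ccccc21`: 27500 nM
Compound 2, `CCN(CC)CN1C(=O)/C(=N\c2nc3ccc(C)cc3s2)c2c(Br)cccc21`: 34300 nM

In an ADME assay on 184B5 cells (Homo sapiens) for cytotoxicity, read by sulforhodamine B assay, with a stated time of 48 h (a higher number here means a weaker inhibitor of growth, a lower number a stronger inhibitor of growth), compound 1 gives 27500 nM. In this assay compound 2 gives 34300 nM, the higher of the two numbers, though the step of a 1.2-fold higher number from compound 1 to compound 2 (0.10 log units; within the scatter) lies within the scatter, so the two compounds cannot be told apart on these figures.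

Compound 3, `CCN(CC)CN1C(=O)/C(=N\c2nc3ccc(C)cc3s2)c2c(Cl)cccc21`, has not yet been measured in this assay. It differs from compound 2 in one place: chloro in place of bromo on an aromatic carbon. For the measured compounds named here, only one measured step bears on this change, the step of a 1.2-fold higher number from compound 1 to compound 2 (0.10 log units; within the scatter), in which a bromo entered at the same place and the number barely moved. Exchanging one halogen for another at that place is therefore expected to give no step beyond the scatter, so for compound 3 the expected step is a 1.1-fold lower number from compound 2 to compound 3 (0.03 log units; within the scatter). Compound 3 is accordingly estimated at 32000 nM, in the range 16000 nM to 64000 nM.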

Compound 3, concentration for 50% growth inhibition: 87800 nM
For compound 3 the middle estimate is 2.7-fold (0.44 log units) below the measured one, outside the stated range (above it).
By their numbers in this assay, from the lowest: compounds 1 and 2 (each within the scatter of the next); then compound 3.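

In this assay this position proves sensitive to which halogen it carries: chloro in place of bromo gives a 2.6-fold higher number from compound 2 to compound 3 (0.41 log units; beyond the scatter) and so a real, if modest, change. Chloro also stands apart from hydrogen at the same place, with a 3.2-fold higher number from compound 1 to compound 3 (0.50 log units; beyond the scatter) in the direction of a weaker inhibitor of growth, whereas bromo in place of hydrogen gave no step beyond the scatter. The two halogens therefore cannot be treated as interchangeable on this aromatic carbon, at least in this pair of compounds. As far as these compounds go, whether a fluoro, a methoxy or an amine at this place would follow chloro or bromo remains open, as does whether the same difference between the halogens would appear on another carbon of the ring. Nothing shown here accounts for the difference between chloro and bromo at this position.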